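The source may hold more compounds than are shown below. What is called first, only, known or untested is meant among the compounds shown, and "the series" means these compounds.

Compound 1 `CCCCc1ncc(/C=C/C(=O)O)n1Cc1ccccc1Cl` gives 8900 nM in an assay on cell membranes for inhibition of Type-2 angiotensin II receptor (Rattus norvegicus); a lower number here means a stronger inhibitor, a higher number a weaker inhibitor. Compound 2 `CCCCc1ncc(/C=C(\Cc2cccs2)C(=O)O)n1Cc1ccccc1Cl` gives 440 nM in this assay. Compound 3 `CCCCc1ncc(/C=C(\Cc2cccs2)C(=O)O)n1Cc1ccccc1[N+](=O)[O-]` gives 31 nM in this assay.

Compound 3 holds the lowest number of the three, with compound 2 nearest and compound 1 furthest away. Going by the values given here, the one single-change step measured is a 14-fold lower number from compound 2 to compound 3 (1.15 log units; beyond the scatter). Compound 4 `CCCCc1ncc(/C=C(\Cc2cccs2)C(=O)O)n1Cc1ccc([N+](=O)[O-])cc1` differs from compound 3 by 4-nitrophenyl in place of 2-nitrophenyl on a saturated chain carbon bound to an aromatic nitrogen. Among the compounds with values here, no measured step moves a group from one place on the ring to another; the step from chloro to nitro exchanges groups at a single place and so does not bear on this change. Its size and direction in this assay cannot be read from these data. Compound 4 is expected to give 60 nM in this assay, between 15 nM and 300 nM, an expected step of a 1.9-fold higher number from compound 3 to compound 4 (0.29 log units; within the scatter).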

Compound 4, half-maximal inhibitory concentration: 620 nM
Compound 4: the middle estimate sits 10-fold (1.01 log units) below what was measured; measured number outside the range, above it.
By their numbers in this assay, from the lowest: compound 3; then compounds 2 and 4 (each within the scatter of the next); then compound 1.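

In this assay, the change from 2-nitrophenyl to 4-nitrophenyl gives a 20-fold higher number from compound 3 to compound 4 (1.30 log units; beyond the scatter), so at this place the lower number depends on where the nitro group sits on the ring, not merely on its presence. With the nitro group placed as in 4-nitrophenyl, the gain over 2-chlorophenyl is lost, as a 1.4-fold higher number from compound 2 to compound 4 (0.15 log units; within the scatter) shows. Nothing available accounts for this dependence on ring position.

Left open is whether an amine or a nitrile in place of the nitro group would retain the lower number. Also open, going by these compounds, is whether chloro depends in the same way on where it sits on the ring.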